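A few compounds are considered here, and "the series" means these few. Any claim that something is new, unique, unknown or untested is made for them only; others in the source may bear on it.

In a functional assay on A549 cells (Homo sapiens) for antiproliferative activity, read by sulforhodamine B assay, with a stated time of 72 h (on this read-out lower numbers stand for stronger inhibition and higher numbers for weaker inhibition), compound 1 `COc1ccc(/C=C2\CCC=CC2=O)cc1[N+](=O)[O-]` gives 1480 nM. Compound 2 `Cn1cc(/C=C2\CCC=CC2=O)c2ccccc21` gives 4920 nM. Compound 3 `COc1cc(/C=C2\CN(C(=O)OCc3ccccc3)C=CC2=O)cc(OC)c1OC` gives 21300 nM, the highest number of the three and so the weakest inhibition among them, with its distance to both compound 1 and compound 2 lying beyond the scatter.

The next compound, compound 4 `COc1cc(/C=C2\CN(S(=O)(=O)c3ccc(C)cc3)C=CC2=O)cc(OC)c1OC`, has not yet been measured. It carries (4-methylphenyl)sulfonyl in place of benzyloxycarbonyl on an amine nitrogen in a ring, and the difference is (4-methylphenyl)sulfonyl in place of benzyloxycarbonyl on an amine nitrogen in a ring. For the measured compounds named here, no pair of measured compounds isolates this change, so the data give no direct guide to its size.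

A moderate step toward a lower number, meaning stronger inhibition, is nevertheless expected in this assay. The support for this is thin: compound 3 stands at 21300 nM, at the top of the measured range, so there is more room below it than above it. The expected change is a 2.7-fold lower number from compound 3 to compound 4 (0.43 log units; beyond the scatter), although a result within the scatter of compound 3 would not be surprising. For compound 4 the estimated value is 8000 nM, with an expected range of 2000 nM to 30000 nM.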

Compound 4, half-maximal inhibitory concentration: 20200 nM
The estimate for compound 4 lay 2.5-fold (0.40 log units) below the measured number; low and high end bracket the measured number.
By their numbers in this assay, from the lowest: compound 1; then compound 2; then compounds 4 and 3 (each within the scatter of the next).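

For the compounds shown here, the exchange on the amine nitrogen in the ring is the first change in this set that can be read on its own. In this assay it gives a 1.1-fold lower number from compound 3 to compound 4 (0.02 log units; within the scatter), so at this position (4-methylphenyl)sulfonyl and benzyloxycarbonyl cannot be told apart. The two groups match in their counted features, with 10 heavy atoms and one six-membered aromatic ring of carbon only each, and replacing one with the other leaves the antiproliferative read-out of compound 3 and compound 4 unchanged within the scatter, although nothing available explains why the two groups read alike.

Both groups carry an aromatic ring, so the compounds shown leave open whether a methyl, an acetyl group or a free amine hydrogen on this nitrogen would shift the number, or whether this position matters little on this core. They also leave open whether the same equivalence between the two groups would hold if the other substituents on the shared core were different.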